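A few compounds are considered here, and "the series" means these few. Any claim that something is new, unique, unknown or untested is made for them only; others in the source may bear on it.

Compound 1, `CCN(CC)CCNC(=O)CC(CC(=O)NC1Cc2ccccc2C1)c1ccc(Cl)cc1`, gives in a functional assay on L02 cells (Homo sapiens) for inhibition (on this read-out lower numbers stand for stronger inhibition and higher numbers for weaker inhibition), a value of 76700 nM.
Compound 2, `CCN(CC)CCNC(=O)CC(CC(=O)NC1Cc2ccccc2C1)c1ccccc1`, gives in this assay only a limit of the assay, > 100000 nM.
Compound 3, `CN(C(=O)CC(CC(=O)NCCN1CCCC1)c1ccccc1)C1Cc2ccccc2C1`, gives in this assay only a limit of the assay, > 100000 nM.

From compound 2 to compound 1 the change is chloro in place of hydrogen on an aromatic carbon, and it brought an at least 1.3-fold lower number from compound 2 to compound 1 (0.11 log units; that floor lies within the scatter). The difference between the core of compound 2 and the core of compound 3 is not broken down here. Compound 4, `CN(C(=O)CC(CC(=O)NCCN1CCCC1)c1ccc(Cl)cc1)C1Cc2ccccc2C1`, is still to be measured; it stands to compound 3 as compound 1 stands to compound 2, carrying the same change, (chloro in place of hydrogen on an aromatic carbon). Only a small step is expected, because an at least 1.3-fold lower number from compound 2 to compound 1 (0.11 log units; that floor lies within the scatter) was itself small, and because the limit of > 100000 nM in this assay, at which 2 of the 3 values shown sit, shows where most values sit. For compound 4 the expected step is an at least 1.1-fold lower number from compound 3 to compound 4 (0.04 log units; that floor lies within the scatter). Compound 4 is expected to give about 90000 nM, with a real chance that only a limit is reported.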

Compound 4, half-maximal inhibitory concentration: 81500 nM
Beside the measured number, compound 4's estimate is 1.1-fold (0.04 log units) above it, within the range that was stated.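

In this assay, chloro in place of hydrogen on the second core brought an at least 1.2-fold lower number from compound 3 to compound 4 (0.08 log units; that floor lies within the scatter). Going by these compounds, on both cores the chloro compound gives a measured number while its hydrogen partner gives only a limit, yet the true size of each step stays unknown and the two steps cannot be told apart: the same change on two cores in this assay, an at least 1.3-fold lower number (0.11 log units; that floor lies within the scatter) from compound 2 to compound 1 and an at least 1.2-fold lower number (0.08 log units; that floor lies within the scatter) from compound 3 to compound 4; the limit leaves it open whether they differ. Limits are common in this small set, which restricts what any such comparison can show: the limit of > 100000 nM in this assay, at which 2 of the 4 values shown sit.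

Still open, on these data alone, is whether another group in the same place, such as fluoro, methoxy or a carboxylic acid, would give a similar result. Also open, as far as these compounds go, is whether the change would carry over to a core with a longer chain ending in the amine.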